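A few compounds are considered here, and "the series" means these few. Any claim that something is new, unique, unknown or untested is made for them only; others in the source may bear on it.

Working notes on the series.

Of the compounds shown here, three have been measured in a functional assay on the whole organism with Scenedesmus acutus as the target, with a stated time of 20 h; on this read-out higher numbers stand for weaker inhibition and lower numbers for stronger inhibition. Compound 2 `CC(C)COC(=O)c1cc(N2C(=O)C3=C(CCCC3)C2=O)ccc1Cl` gives 15500 nM. Compound 1 `CC(C)COC(=O)c1cc(N2C(=O)C3=C(CCCC3)C2=O)c(F)cc1Cl` gives 407 nM in this assay. Compound 3 `CCC(C)OC(=O)c1cc(N2C(=O)C3=C(CCCC3)C2=O)ccc1Cl` gives 9770 nM in this assay.

Compound 1 differs from compound 2 by fluoro in place of hydrogen on an aromatic carbon, and that single change produced the step of a 38-fold lower number from compound 2 to compound 1 (1.58 log units; beyond the scatter). Compound 3 differs from compound 2 by sec-butyl in place of isobutyl on an oxygen next to a carbonyl group; the step of a 1.6-fold lower number from compound 2 to compound 3 (0.20 log units; within the scatter) lies within the scatter, so the two cores are not separated by this read-out.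

Compound 4 `CCC(C)OC(=O)c1cc(N2C(=O)C3=C(CCCC3)C2=O)c(F)cc1Cl` is not yet measured. It differs from compound 3 by fluoro in place of hydrogen on an aromatic carbon. For the measured compounds named here, this is the same kind of change as the one from compound 2 to compound 1, not the same one: the place descriptions agree except that the ring carbon is para to a sec-butoxycarbonyl group in compound 4 where it was para to an isobutoxycarbonyl group in compound 1.

Going by the values given here, only one measured pair carries this change, so the expectation rests on a single step. The step from compound 3 to compound 4 is expected to be a 38-fold lower number from compound 3 to compound 4 (1.57 log units; beyond the scatter), close to the earlier step, because the earlier step of a 38-fold lower number from compound 2 to compound 1 (1.58 log units; beyond the scatter) was large and because the cores cannot be told apart per a 1.6-fold lower number from compound 2 to compound 3 (0.20 log units; within the scatter). Compound 4 is therefore estimated at 260 nM in this assay, expected to fall between 100 nM and 700 nM.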

Compound 4, half-maximal inhibitory concentration: 74.1 nM
The estimate for compound 4 lay 3.5-fold (0.55 log units) above the measured number; the measured number lies below the stated range.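

The fluoro in place of hydrogen carries over to the core of compound 3 in the same direction, and the step is again large, with a 130-fold lower number from compound 3 to compound 4 (2.12 log units; beyond the scatter) in this assay; its size, however, does not carry over, as the two steps differ by more than the scatter: the same change on two cores in this assay, a 38-fold lower number (1.58 log units; beyond the scatter) from compound 2 to compound 1 and a 130-fold lower number (2.12 log units; beyond the scatter) from compound 3 to compound 4, 3.5-fold (0.54 log units) apart, beyond the scatter of two such steps.

Seen from the other side of the same four compounds, sec-butyl in place of isobutyl cannot be read on the cores without fluoro but gives a 5.5-fold lower number from compound 1 to compound 4 (0.74 log units; beyond the scatter) on the fluoro cores, so the step for this change also depends on the core: the same change on two cores in this assay, a 1.6-fold lower number (0.20 log units; within the scatter) from compound 2 to compound 3 and a 5.5-fold lower number (0.74 log units; beyond the scatter) from compound 1 to compound 4, 3.5-fold (0.54 log units) apart, beyond the scatter of two such steps.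

These two comparisons describe one set of four compounds in a single assay, so they show that the two changes do not simply add here, but they do not show why, and they give no size to expect for the fluoro step on any other core.

Open, from the compounds shown here alone, is whether the larger fluoro step persists with a longer chain or a cyclopentyl group in place of sec-butyl on the oxygen next to the carbonyl group. Also open, going by these compounds, is whether chloro or a nitrile on that aromatic carbon would give a step like that of fluoro.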